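Cyano in place of nitro on the pyridine of compound 3

This account rests on a few compounds, and the source may have more. Where it says the series, first, only, none or still open, it means among the compounds named here.

Compound 1 `CC1(C)[C@@H]2CC[C@@]1(CS(=O)(=O)N1CCN(c3ncccc3C(F)(F)F)CC1)C(=O)C2`; in a functional assay on CHO-K1 cells for antagonist activity at C-X-C chemokine receptor type 3 (Homo sapiens), read by FLIPR and calcium flux (a higher number here means a weaker inhibitor, a lower number a stronger inhibitor), compound 1 gives > 31600 nM, a limit of the assay.
Compound 2 `CC1(C)[C@@H]2CC[C@@]1(CS(=O)(=O)N1CCN(c3ccc(Br)cn3)CC1)C(=O)C2`; in this assay compound 2 gives 1580 nM.
Compound 3 `CC1(C)[C@@H]2CC[C@@]1(CS(=O)(=O)N1CCN(c3ccc([N+](=O)[O-])cn3)CC1)C(=O)C2`; in this assay compound 3 gives > 31600 nM, which is again a limit of the assay.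

Compound 3 thus stands at the top of the numbers shown, at the limit of > 31600 nM in this assay, at which 2 of the 3 values shown sit, where compound 1 also sits; only compound 2 gives a number. The measured steps are an at least 20-fold lower number from compound 1 to compound 2 (1.30 log units; beyond the scatter), an at least 20-fold higher number from compound 2 to compound 3 (1.30 log units; beyond the scatter) and a step that the two limits leave unreadable from compound 1 to compound 3. Compound 4 `CC1(C)[C@@H]2CC[C@@]1(CS(=O)(=O)N1CCN(c3ccc(C#N)cn3)CC1)C(=O)C2` differs from compound 3 by cyano in place of nitro on an aromatic carbon. For the measured compounds named here, the step that bears on this is the large one from compound 2 to compound 3, where bromo gave a number and nitro gave only a limit; no cyano analogue has been measured, so the effect of cyano on its own is unknown. Because compound 3 gives only > 31600 nM, the size of any expected step from compound 3 to compound 4 cannot be read. Compound 4 is estimated at 15000 nM, with a range from 3000 nM to 40000 nM.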

Compound 4, half-maximal inhibitory concentration: > 31600 nM
Compound 4 ended at the assay's limit (the forecaster's own chance of this, stated with the estimate: 45%); middle value at least 2.1-fold (0.32 log units) from the limit.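

With cyano in place of bromo on this aromatic carbon, para to a large group, this assay shows an at least 20-fold higher number from compound 2 to compound 4 (1.30 log units; beyond the scatter), so a second group at this position, one with fewer heavy atoms than nitro, fails to keep the number that bromo gave. The steps from compound 3 to compound 4 and from compound 1 to compound 4 cannot be read, as both ends of each are limits. Bromo therefore remains the only one of the three groups at this position to give a number, while the rest of the series gathers at a single ceiling: the limit of > 31600 nM in this assay, at which 3 of the 4 values shown sit.

Whether nitro and cyano differ at all stays hidden behind that limit. The compounds shown also leave open how chloro, methyl, methoxy or an amine at this position would compare with bromo on the same core.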